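A few compounds are considered here, and "the series" means these few. Any claim that something is new, unique, unknown or untested is made for them only; others in the source may bear on it.

In a physicochemical assay for lipophilicity, at pH 7.4 (on this read-out lower numbers stand for lower lipophilicity and higher numbers for higher lipophilicity), compound 2 `Cc1nc(C)c(-c2nnc(-c3ccc(OC(C)C)c(Cl)c3)s2)s1` gives 7.76, the highest of the three measured numbers. Compound 1 `CC(C)Oc1ccc(-c2nnc(-n3cc4c(n3)CCN(CCC(=O)O)C4)s2)cc1Cl` stands at 3.26 and compound 3 `CC(C)Oc1ccc(-c2nnc(-n3cc4c(n3)CCN(CCC(=O)O)C4)s2)cc1C#N` at 2.58, both far lower. Compound 4 `CC(C)Oc1ccc(-c2nnc(-c3cn[nH]c3)s2)cc1Cl` differs from compound 2 in one place: 1H-pyrazol-4-yl in place of 2,4-dimethyl-1,3-thiazol-5-yl on an aromatic carbon. For the measured compounds named here, the only measured step, a number 0.68 log units lower from compound 1 to compound 3 (beyond the scatter), is a different change, cyano in place of chloro, so it offers a rough scale and no direct guide. A larger step than that one is expected here, downward in this assay, because compound 2 starts at 7.76, far above the others. The expected step is a number 2.16 log units lower from compound 2 to compound 4 (beyond the scatter). Compound 4 is estimated at 5.6, within a range of 4.6 to 6.6.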

Compound 4, distribution coefficient: 5
Compound 4: the middle estimate sits 0.60 log units above what was measured, and the stated range covers the measured number.
By their numbers in this assay, from the lowest: compound 3; then compound 1; then compound 4; then compound 2.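

In this assay, 1H-pyrazol-4-yl in place of 2,4-dimethyl-1,3-thiazol-5-yl gives a number 2.76 log units lower from compound 2 to compound 4 (beyond the scatter), which shows that the read-out at this aromatic carbon depends strongly on the group it carries. The entering ring has fewer heavy atoms and brings a hydrogen-bond donor that the leaving ring lacks, and this single change cannot separate those differences. Nothing measured here accounts for the size of the step. Still open, from the compounds shown here alone, is how a methyl group or an amine on the 1H-pyrazol-4-yl would move the number.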